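This account rests on a few compounds, and the source may have more. Where it says the series, first, only, none or still open, it means among the compounds named here.

Measured so far:
Compound 1 `CC(C)(C)C(=O)NCCCCN1CCN(c2ccc(Cl)cc2)CC1` in an assay on HEK293 cells for binding affinity to D(4) dopamine receptor (Homo sapiens), read by radioligand binding (a lower number here means a stronger inhibitor, a higher number a weaker inhibitor), gives 12.6 nM.
Compound 2 `CC(=O)NCCCCN1CCN(c2ccc(Cl)cc2)CC1` in this assay gives 1260 nM.

Going by the values given here, compound 2 has the highest of the two numbers, and the only step that bears on the change to compound 3 `CC(C)C(=O)NCCCCN1CCN(c2ccc(Cl)cc2)CC1` is the one a 100-fold higher number from compound 1 to compound 2 (2.00 log units; beyond the scatter). The difference is isopropyl in place of methyl on a carbonyl carbon. Since isopropyl stands between methyl and tert-butyl, a smaller but still clear gain is expected for compound 3, with an estimated step of a 9.7-fold lower number from compound 2 to compound 3 (0.99 log units; beyond the scatter) in this assay. Compound 3 is therefore expected to give about 130 nM, between 30 nM and 500 nM.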

Compound 3, inhibition constant: 126 nM
Compound 3: middle estimate off by 1.0-fold (0.01 log units), on the high side; low and high end bracket the measured number.
By their numbers in this assay, from the lowest: compound 1; then compound 3; then compound 2.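

On the carbonyl carbon, isopropyl in place of methyl gives a 10-fold lower number from compound 2 to compound 3 (1.00 log units; beyond the scatter), while hydrogen in place of methyl on the saturated chain carbon bound to that carbonyl carbon gives a 10-fold higher number from compound 1 to compound 3 (1.00 log units; beyond the scatter). Compound 3 thus places an intermediate stage within the gap that the earlier pair showed only as a whole, and the two steps are the same size in this assay. Nothing measured here accounts for these steps. Open, on these data alone, is how a cyclopropyl or phenyl group on the carbonyl carbon would compare, and whether a longer chain in place of the butyl linker would preserve this order.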